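Amino to azo-salicylate swap on two related cores

The compounds below may be only part of what the source reports. "The series", "measured", "known", "first", "only" and "open" are said of these compounds alone.

Measured compounds in a functional assay on the whole organism with Oryctolagus cuniculus as the target; a lower number here means a stronger inhibitor, a higher number a weaker inhibitor:
compound 1 `CCOC(=O)[C@H](CC(C)C)N(C(=O)c1ccc(N)cc1)S(=O)(=O)c1ccc(Cn2c(C)nc3cnccc32)cc1` gives 30 nM
compound 2 `CCOC[C@H](CC(C)C)N(Cc1ccc(N)cc1)S(=O)(=O)c1ccc(Cn2c(C)nc3cnccc32)cc1` gives 16 nM
compound 3 `CCOC[C@H](CC(C)C)N(Cc1ccc(/N=N\c2ccc(O)c(C(=O)O)c2)cc1)S(=O)(=O)c1ccc(Cn2c(C)nc3cnccc32)cc1` gives 400 nM

Compound 1 and compound 2 are within the usual scatter of each other, so no order is drawn between them. The two cores differ in a way that is not broken down here. Compound 3 carries the change a group of 12 heavy atoms (7 carbon, 2 nitrogen, 3 oxygen; one six-membered aromatic ring of carbon only) in place of one nitrogen atom, on an aromatic carbon on the core of compound 2, and the step of a 25-fold higher number from compound 2 to compound 3 (1.40 log units; beyond the scatter) is large and beyond the scatter.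

Compound 4 `CCOC(=O)[C@H](CC(C)C)N(C(=O)c1ccc(/N=N\c2ccc(O)c(C(=O)O)c2)cc1)S(=O)(=O)c1ccc(Cn2c(C)nc3cnccc32)cc1` has not been measured. It stands to compound 1 as compound 3 stands to compound 2: the change a group of 12 heavy atoms (7 carbon, 2 nitrogen, 3 oxygen; one six-membered aromatic ring of carbon only) in place of one nitrogen atom, on an aromatic carbon is the same change, at the same place, since both "place" descriptions agree word for word. Among the compounds shown this change has one measured example only, so the expectation for compound 4 rests on compound 2 and compound 3 alone, through a 25-fold higher number from compound 2 to compound 3 (1.40 log units; beyond the scatter), and on the starting value of compound 1, 30 nM.

In this assay, for the measured compounds named here, the step from compound 1 to compound 4 is expected to be a 23-fold higher number from compound 1 to compound 4 (1.37 log units; beyond the scatter), of about the same size as the measured one, because a 25-fold higher number from compound 2 to compound 3 (1.40 log units; beyond the scatter) is the only guide and the unchanged parts of the two cores are not separated here. Going by the values given here, compound 4 is therefore estimated at 700 nM, with a range from 250 nM to 2500 nM to allow for the single precedent and the scatter of this kind of measurement.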

Compound 4, half-maximal inhibitory concentration: 1470 nM
For compound 4 the middle estimate is 2.1-fold (0.32 log units) below the measured one; the measured number falls inside the stated range.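

Exchanging the amino group for the group of 12 heavy atoms, on an aromatic carbon para to a large group, gives in this assay a 49-fold higher number from compound 1 to compound 4 (1.69 log units; beyond the scatter) and so marks a large weakening on the core of compound 1 as well. On the two cores at hand the change therefore carries over, with a weaker inhibitor each time and steps that cannot be told apart, but two examples set no rule for any further core and say nothing about why the step is this large. The two steps compare as follows: the same change on two cores in this assay, a 25-fold higher number (1.40 log units; beyond the scatter) from compound 2 to compound 3 and a 49-fold higher number (1.69 log units; beyond the scatter) from compound 1 to compound 4, 2.0-fold (0.29 log units) apart, within the scatter of two such steps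

The group enters whole, so the compounds shown leave open how much of the step belongs to the azo link, the phenyl ring, the hydroxyl or the carboxylic acid, a question that an azo-linked phenyl ring with no hydroxyl and no carboxylic acid, or an acetyl group on the amino nitrogen, would bear on. Also open, going by these compounds, is whether the step keeps its size on a core that differs from these two in one place only, such as the core of compound 1 with the ethyl ester replaced by an ethoxymethyl group and its carbonyl kept.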